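The compounds below may be only part of what the source reports. "The series", "measured", "known", "first", "only" and "open" are said of these compounds alone.

an ADME assay on J774 cells (Mus musculus, strain BALB/c) for cytotoxicity, read by resazurin assay, with a stated time of 72 h (a higher number here means that more compound is tolerated, a lower number that less compound is tolerated), was used to compare three hydrazone amides that share one core. Compound 1 `COc1ccc(C(=O)N/N=C(C)/C=N/Nc2ccc([N+](=O)[O-])cc2)cc1` gives only a limit in this assay, > 100000 nM. Compound 2 `CC(/C=N/Nc1ccc([N+](=O)[O-])cc1)=N\NC(=O)c1ccccc1N`, with 2-aminophenyl in place of 4-methoxyphenyl on a carbonyl carbon, gives 29800 nM in this assay, which is an at least 3.3-fold lower number from compound 1 to compound 2 (0.52 log units; beyond the scatter). Compound 3 `CC(/C=N/Nc1ccc([N+](=O)[O-])cc1)=N\NC(=O)c1ccc(C(C)(C)C)cc1` also reports only a limit in this assay, > 100000 nM. The step with tert-butyl in place of methoxy on an aromatic carbon is therefore a step that the two limits leave unreadable from compound 1 to compound 3, because the limit of > 100000 nM in this assay, at which 2 of the 3 values shown sit, leaves it unreadable. Compound 3 thus stands at the upper edge of what this assay can report.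

Compound 4 `CC(/C=N/Nc1ccc([N+](=O)[O-])cc1)=N\NC(=O)c1ccc(O)cc1` differs from compound 3 by hydroxy in place of tert-butyl on an aromatic carbon. Among the compounds with values here, only the unreadable step from compound 1 to compound 3 touches this position, while the one readable step, made at a different position and giving compound 2, shows that a change on this ring can lower the number by a modest amount. Compound 4 is expected to remain at or near the limit, with an estimated step of a number no higher from compound 3 to compound 4 (the limit leaves the size open). The expected value for compound 4 is 100000 nM, within 30000 nM to 300000 nM.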

Compound 4, half-maximal cytotoxic concentration: 51000 nM
Compound 4: middle estimate off by 2.0-fold (0.29 log units), on the high side, within the range that was stated.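

Within the data shown here, compound 4 gives the first number at this position of the ring that is not a limit in this assay. The change from tert-butyl to hydroxy gives an at least 1.9-fold lower number from compound 3 to compound 4 (0.29 log units; that floor lies within the scatter), and removing the methyl from the oxygen of the methoxy group gives an at least 1.9-fold lower number from compound 1 to compound 4 (0.29 log units; that floor lies within the scatter), but the true size of each step cannot be read because of the limit: the limit of > 100000 nM in this assay, at which 2 of the 4 values shown sit. Moving to 4-hydroxyphenyl from 2-aminophenyl gives a 1.7-fold higher number from compound 2 to compound 4 (0.23 log units; within the scatter), so these two numbers cannot be told apart, and a change at this position can reach the same range as the earlier change on this ring.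

The compounds shown leave open whether the number follows the hydrogen-bond donor that enters or the tert-butyl that leaves. An amine or a carboxylic acid at this same place would help to separate the two.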